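Trifluoromethyl to dimethoxy: compound 3 to compound 4

The source may hold more compounds than are shown below. What is called first, only, known or untested is meant among the compounds shown, and "the series" means these compounds.

Values in a functional assay on a cell-free system (Platelet, plasma, Homo sapiens) for inhibition; a higher number here means a weaker inhibitor, a lower number a stronger inhibitor:
- compound 1 `Cc1ccc(N(CCN2CCC(OCC(=O)O)CC2)C(=O)c2ccc(C(F)(F)F)cc2)cc1`: > 10000 nM (a limit of the assay, not a number)
- compound 2 `COc1cccc(C(=O)N(CCN2CCC(OCC(=O)O)CC2)c2ccc(C)cc2)c1`: 32 nM
- compound 3 `Cc1ccc(N(CCN2CCC(OCC(=O)O)CC2)C(=O)c2cccc(C(F)(F)F)c2)cc1`: 20000 nM

Compound 3 holds the higher of the two readable numbers in this assay, and compound 2 holds the other. Compound 1 gives only a limit, so its place relative to compound 3 cannot be read.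

The next compound is compound 4 `COc1ccc(C(=O)N(CCN2CCC(OCC(=O)O)CC2)c2ccc(C)cc2)cc1OC`, with 3,4-dimethoxyphenyl in place of 3-(trifluoromethyl)phenyl on a carbonyl carbon.

Going by the values given here, two measured steps bear on this change, and both are large and beyond the scatter. The closest is a 630-fold higher number from compound 2 to compound 3 (2.80 log units; beyond the scatter), which connects methoxy and trifluoromethyl directly. The other, read against the limit, is an at least 310-fold lower number from compound 1 to compound 2 (2.49 log units; beyond the scatter). Among these three compounds, the one with methoxy gives the low number and the two with trifluoromethyl give high readings. Among the compounds with values here, no measured compound shows the effect of the extra methoxy group on its own, so the range is kept wide.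

A large step toward a lower number is expected, estimated as a 330-fold lower number from compound 3 to compound 4 (2.52 log units; beyond the scatter). For compound 4 the estimated value is 60 nM, with an expected range of 10 nM to 600 nM.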

Compound 4, half-maximal inhibitory concentration: > 3000 nM
Compound 4: only a limit was reported; the forecaster's own chance of this, stated with the estimate: 5%; middle value at least 50-fold (1.69 log units) away from the limit.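

Compound 4 stands in this assay only as a limit, not a number: the limit of > 3000 nM in this assay, at which 1 of the 4 values shown sits.

Set against compound 2, the one added methoxy on an aromatic carbon gives an at least 93-fold higher number from compound 2 to compound 4 (1.97 log units; beyond the scatter), so a large change at this aryl group on the carbonyl carbon now appears without any trifluoromethyl group involved, and the low reading of compound 2 does not extend to every methoxy-bearing ring here. Compound 2 is thus the only one of the four with a readable low number, and the steps from compound 1 and compound 3 to compound 4 cannot be read, which leaves compound 4 unordered against both trifluoromethyl compounds.

The compounds shown leave open how far the number rises beyond the limit of compound 4, and whether the added methoxy group acts through its own presence or through the 3,4-dimethoxyphenyl pattern as a whole. A plain phenyl on the carbonyl carbon would give the reference that is absent from this set, and a hydroxy or fluoro group in place of the added methoxy would test whether any group at that place has the same outcome.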